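Replacing a pyridine on the piperazine with a cycloheptyl ring

The source may hold more compounds than are shown below. What is called first, only, known or untested is meant among the compounds shown, and "the series" means these compounds.

Among the compounds with values here, compound 2 `Nc1scc(CN2CCN(c3cccnc3)CC2)c1C(=O)c1ccc(Cl)cc1` is one of two compounds measured in a functional assay on CHO cells with adenosine receptor A1 (Homo sapiens) as the target, read by cAMP accumulation and immunoassay, with a stated time of 6 min, tested at 0.1 uM; a lower number here means a stronger effect, a higher number a weaker effect of the compound at the concentration tested. In this assay compound 2 gives 3.4%, and compound 1 `Nc1scc(CN2CCN(c3ccc(Cl)cc3F)CC2)c1C(=O)c1ccc(Cl)cc1` gives -9.4%. Between them stands a single change on the ring amine nitrogen, and the shift of a number 12.8 percentage points higher from compound 1 to compound 2 (beyond the scatter) leaves compound 2 with the higher of the two numbers, though both sit close to zero. Compound 3 `Nc1scc(CN2CCN(C3CCCCCC3)CC2)c1C(=O)c1ccc(Cl)cc1` alters the same position of the shared core once more: cycloheptyl in place of pyridin-3-yl on an amine nitrogen in a ring. Within the data shown here, no measured step swaps an aromatic group for a saturated ring at this position, so the only guidance is that the one change seen there moved the read-out only modestly and that neither measured compound shows a strong effect. A step of about a number 3.4 percentage points lower from compound 2 to compound 3 (within the scatter) is therefore expected, within the scatter. Compound 3 is estimated to give 0%, with a likely range from -15% to 15%.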

Compound 3, a percentage reported as activity, at one concentration (the size of the read-out at that concentration, not a potency): 13%
Compound 3: the middle estimate sits 13 percentage points below what was measured; the range from low to high includes it.
By their numbers in this assay, from the lowest: compound 1; then compounds 2 and 3 (each within the scatter of the next).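

In this assay, within the data shown here, a saturated ring of carbon only now stands at this position for the first time, and cycloheptyl in place of pyridin-3-yl gives a number 9.6 percentage points higher from compound 2 to compound 3 (within the scatter) with no change that can be told from scatter, even though the ring nitrogen and its hydrogen-bond acceptor are gone. Set against the 4-chloro-2-fluorophenyl group, the same ring gives a number 22.4 percentage points higher from compound 1 to compound 3 (beyond the scatter) and so compound 1 stands apart from compound 3, yet all three numbers remain small. Nothing measured here gives a reason for these numbers.

Going by these compounds, whether an open chain such as n-butyl, or a ring holding an oxygen such as tetrahydropyranyl, on the same ring nitrogen would move the number further remains open. A reading at a single concentration also gives no potency for any of the three compounds.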